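Trading dichlorophenoxy for fluorophenoxy on a shared quinoxaline core

A few compounds are considered here, and "the series" means these few. Any claim that something is new, unique, unknown or untested is made for them only; others in the source may bear on it.

Compound 1, `Nc1cc(N)c2nc(-c3ccccc3)c(Oc3ccc(Cl)c(Cl)c3)nc2c1`, was tested in a functional assay on OVCAR-3 cells (Homo sapiens) for inhibition, read by sulforhodamine B assay, with a stated time of 48 h (on this read-out lower numbers stand for higher toxicity in this test and higher numbers for lower toxicity in this test), where compound 1 gives 66100 nM. Within the data shown here, that is the only numeric value in this set. Compound 2, `CCOC(=O)[C@H](CCC(=O)O)NC(=O)c1ccc(Sc2nc3cc(N)cc(N)c3nc2-c2ccccc2)cc1`, is also described in this assay, but for compound 2 the result of < 100000 nM is a limit of the assay rather than a number. Compound 3, `Nc1cc(N)c2nc(-c3ccccc3)c(Oc3ccc(F)cc3)nc2c1`, has not yet been measured. It differs from compound 1 in one place: 4-fluorophenyl in place of 3,4-dichlorophenyl on an oxygen on an aromatic ring. Among the measured compounds shown here, no measured pair in this set shows what such a change does. The value of compound 1 already sits close to the edge of what this assay reports, so the step from compound 1 to compound 3 is expected to be small, toward weaker toxicity or none beyond the scatter, an expected 1.4-fold higher number from compound 1 to compound 3 (0.13 log units; within the scatter). Compound 3 is therefore estimated at 90000 nM, expected to fall between 35000 nM and 250000 nM.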

Compound 3, concentration lethal to 50% of the cells: < 100000 nM
Compound 3 was reported as a limit; the forecaster's own chance of this, stated with the estimate: 45%; the middle value is on the limit's open side.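

Compound 3 gives < 100000 nM in this assay, which is a limit and not a number. The step from compound 1 to compound 3 therefore cannot be read: the limit of < 100000 nM in this assay, at which 2 of the 3 values shown sit. The compounds shown leave open what 4-fluorophenyl in place of 3,4-dichlorophenyl does in this assay.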